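This account rests on a few compounds, and the source may have more. Where it says the series, first, only, none or still open, it means among the compounds named here.

In a functional assay on HepG2 cells (Homo sapiens) for antiproliferative activity, read by MTT assay, with a stated time of 72 h (on this read-out higher numbers stand for weaker inhibition and lower numbers for stronger inhibition), three compounds built on a shared core have been measured. Within the data shown here, compound 1 (`COc1ccc(N2C(=O)COc3ccc(-c4ccc(O)cc4)cc32)cc1`) gives 10800 nM, the only true number in the set. Compound 2 (`COc1ncc(-c2ccc3c(c2)N(C2CCCCC2)C(=O)CO3)cc1NS(=O)(=O)c1ccc(F)cc1`) reads > 40000 nM, which is a limit of the assay and not a number. Compound 3 (`COc1cccc(N2C(=O)COc3ccc(-c4cccc(NS(=O)(=O)c5ccc(F)cc5)c4)cc32)c1`) reads > 40000 nM, which is likewise a limit and not a number. Compound 3 therefore stands at the limit of > 40000 nM in this assay, at which 2 of the 3 values shown sit, with no number of its own.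

Compound 4 (`O=C1COc2ccc(-c3cccc(NS(=O)(=O)c4ccc(F)cc4)c3)cc2N1c1ccccc1`) differs from compound 3 in one place, where 3-methoxyphenyl becomes phenyl: hydrogen in place of methoxy on an aromatic carbon, (hydrogen in place of methoxy on an aromatic carbon). Among the measured compounds shown here, no measured pair in this set isolates that change, so there is no direct precedent for the size of the step. The expectation rests on compound 3 and its limit of > 40000 nM. No step beyond the usual scatter is expected in this assay, and no firm direction can be assigned, although a limit leaves room only for a modest gain to show up as a number. The estimated change is an at least 1.1-fold lower number from compound 3 to compound 4 (0.05 log units; that floor lies within the scatter). For compound 4 the expected value is 35000 nM, with an estimated range from 12000 nM to 80000 nM.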

Compound 4, half-maximal inhibitory concentration: 30300 nM
Compound 4: the middle estimate sits 1.2-fold (0.06 log units) above what was measured; the range from low to high includes it.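

In this assay, replacing the 3-methoxyphenyl of compound 3 with the phenyl of compound 4 gives this position its first true number, as compound 4 reads 30300 nM. The step is an at least 1.3-fold lower number from compound 3 to compound 4 (0.12 log units; that floor lies within the scatter), and it is only a floor, so the result fixes the lower edge of what losing the methoxy does here, not the full size of the change. Compound 3 gives > 40000 nM, which is a limit and not a number, and that is why the true step cannot be read from this pair: the limit of > 40000 nM in this assay, at which 2 of the 4 values shown sit.

The compounds shown leave open whether the real difference between hydrogen and methoxy on this aromatic carbon lies beyond the usual scatter of the assay, since the floor alone cannot settle that. They also leave open what other groups would do at the same place on the ring, such as a fluorine, a hydroxyl or an amine. Only methoxy and hydrogen appear there, and only one of the two has a true number.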